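This account rests on a few compounds, and the source may have more. Where it says the series, first, only, none or still open, it means among the compounds named here.

Within the data shown here, compound 3, `CCOC(=O)CCCC/C=C(\c1ccccc1)c1cccnc1`, gives 600 nM in an assay (Equus caballus) for inhibition of Thromboxane-A synthase (Homo sapiens), using microsomes (on this read-out higher numbers stand for weaker inhibition and lower numbers for stronger inhibition), the highest of the three numbers so far. Among the measured compounds shown here, compound 2, `NC(=O)CCCC/C=C(\c1ccccc1)c1cccnc1`, sits nearest with 400 nM, and the one measured step, a 1.5-fold higher number from compound 2 to compound 3 (0.18 log units; within the scatter), lies within the scatter. Compound 1, `O=C(O)CCC/C=C(/c1ccccc1)c1cccnc1`, stands furthest off with 280 nM, a gap beyond the scatter.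

Compound 4, `O=C(O)CCC/C=C(\c1ccccc1)c1cccnc1`, differs from compound 3 by carboxy in place of (ethoxycarbonyl)methyl on a saturated chain carbon, three bonds along the chain from a double-bonded chain carbon. For the measured compounds named here, no measured step covers this change directly. The step from amide to ethyl ester, a 1.5-fold higher number from compound 2 to compound 3 (0.18 log units; within the scatter), was small, and the only acid measured, compound 1, gives the lowest number of the set with 280 nM, while compound 4 carries the same carboxy and the same chain length as compound 1 but with the double bond drawn the other way, for which no comparison exists.

On that basis a modest move towards a lower number is expected, a 2.0-fold lower number from compound 3 to compound 4 (0.30 log units; within the scatter), and compound 4 is estimated at 300 nM in this assay, within a range of 80 nM to 1100 nM.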

Compound 4, half-maximal inhibitory concentration: 30 nM
Estimate against measurement, compound 4: 10-fold (1.00 log units) above; measured number below the stated range.
By their numbers in this assay, from the lowest: compound 4; then compounds 1, 2 and 3 (each within the scatter of the next, the first and the last beyond it).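

In this assay the carboxy group on this chain carbon brings a large drop from the ethyl ester (a 20-fold lower number from compound 3 to compound 4 (1.30 log units; beyond the scatter)) and from the amide (a 13-fold lower number from compound 2 to compound 4 (1.12 log units; beyond the scatter)), whereas the earlier exchange between amide and ester had stayed within the scatter (a 1.5-fold higher number from compound 2 to compound 3 (0.18 log units; within the scatter)). The new result also shows that the drawn geometry of the double bond matters at this chain length (a 9.3-fold lower number from compound 1 to compound 4 (0.97 log units; beyond the scatter)). That gap can be put down to the double bond alone, because of one structural fact: the fact that compounds 1 and 4 differ only in the configuration as drawn.

As far as these compounds go, the steps from the ester and the amide change the end group and shorten the chain together, so their separate shares stay unknown. From the compounds shown here alone, a carboxylic acid on the longer chain of compound 2 and compound 3 would separate them, and the double bond's drawn geometry on that longer chain remains open too.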